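The compounds below may be only part of what the source reports. "The series", "measured", "known", "first", "only" and "open" are said of these compounds alone.

Measured compounds in a functional assay on MDA-MB-231 cells (Homo sapiens) for antiproliferative activity, read by sulforhodamine B assay; a lower number here means a stronger inhibitor of growth, a higher number a weaker inhibitor of growth:
Compound 1 `COc1ccc2sc(NC(=O)c3ccc(C(F)(F)F)cc3)nc2c1`: > 10 ug/mL, a limit of the assay rather than a number.
Compound 2 `COc1ccccc1NC(=O)Nc1nc2ccc(F)cc2s1`: > 10 ug/mL, also a limit of the assay.

Compound 1 therefore stands at the limit of > 10 ug/mL in this assay, at which 2 of the 2 values shown sit, so no number places it. Compound 3 `COc1ccc2sc(NC(=O)c3ccc([N+](=O)[O-])cc3)nc2c1` carries a change on the same core: nitro in place of trifluoromethyl on an aromatic carbon. Going by the values given here, no step between measured compounds is known, so the size of the step in this assay can only be expected; an outcome within the scatter seems most likely, with compound 3 staying near the limit. The estimate for compound 3 is 15 ug/mL, between 5 ug/mL and 50 ug/mL, a step that the limit leaves unreadable from compound 1 to compound 3 from compound 1.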

Compound 3, concentration for 50% growth inhibition: > 10 ug/mL
Compound 3: only a limit was reported; the forecaster's own chance of this, stated with the estimate: 70%; the middle value is on the limit's open side.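

Compound 1 and compound 3 both rest on a limit in this assay, so no step between them can be read: the limit of > 10 ug/mL in this assay, at which 3 of the 3 values shown sit.

The compounds shown leave open whether nitro and trifluoromethyl differ at all on the shared core.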